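The compounds below may be only part of what the source reports. "The series", "measured", "known", "first", "only" and "open" are said of these compounds alone.

Cytotoxicity notes on the series. Compound 1 `CCOC(=O)c1c(-c2cccc(OC)c2)[nH]c2cc(F)cc(F)c2c1=O` was tested in an ADME assay on BJ cells (Homo sapiens) for cytotoxicity, read by luminescence, with a stated time of 72 h; a higher number here means that more compound is needed for the effect, a lower number that less compound is needed. In this assay compound 1 gives only a limit, > 21500 nM. Compound 2 `CCOC(=O)c1c(-c2cccc(Oc3ccccc3)c2)[nH]c2cc(F)cc(F)c2c1=O` carries the change (phenyl in place of methyl on an oxygen on an aromatic ring). In this assay compound 2 likewise gives only a limit, > 21500 nM. The step that the two limits leave unreadable from compound 1 to compound 2 therefore cannot be read from the two limits. Compound 3 `CCOC(=O)c1c(-c2cccc(OC)c2)[nH]c2cc(Cl)c(Cl)cc2c1=O` differs from compound 1 in its core; the difference between the two cores is not broken down here. In this assay compound 3 also gives only a limit, > 21500 nM. Compound 4 `CCOC(=O)c1c(-c2cccc(Oc3ccccc3)c2)[nH]c2cc(Cl)c(Cl)cc2c1=O` carries the same change as compound 2, (phenyl in place of methyl on an oxygen on an aromatic ring), at the same place. Going by the values given here, for compound 4 a step that the limit leaves unreadable from compound 3 to compound 4 is expected because the limit of > 21500 nM in this assay, at which 3 of the 3 values shown sit, covers every value measured so far. The estimate for compound 4 is then 30000 nM, most likely reported again as a limit.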

Compound 4, half-maximal effective concentration: > 21500 nM
Compound 4 ended at the assay's limit (the forecaster's own chance of this, stated with the estimate: 85%); the middle value lies beyond the limit too.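

No new step can be read, as compound 3 and compound 4 both give only a limit. The compounds shown leave open at what concentration any of them reaches the effect in this assay, and whether methoxy to phenoxy alters it.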